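The source may hold more compounds than are shown below. What is called first, only, known or untested is meant among the compounds shown, and "the series" means these compounds.

In a functional assay on CHO cells with adenosine receptor A1 (Homo sapiens) as the target, read by cAMP accumulation and immunoassay, with a stated time of 6 min, tested at 0.1 uM (on this read-out lower numbers stand for a stronger effect and higher numbers for a weaker effect at the one concentration tested), compound 3 `Nc1scc(CN2CCN(c3cccc(F)c3)CC2)c1C(=O)c1ccc(Cl)cc1` gives -37%, the lowest of the three numbers: compound 1 `Nc1scc(CN2CCN(c3ccc(Cl)cc3F)CC2)c1C(=O)c1ccc(Cl)cc1` gives -9.4% and compound 2 `Nc1scc(CN2CCN(c3cccc4ccccc34)CC2)c1C(=O)c1ccc(Cl)cc1` gives 0%. The steps of a number 27.6 percentage points lower from compound 1 to compound 3 (beyond the scatter) and a number 37 percentage points lower from compound 2 to compound 3 (beyond the scatter) show that exchanging the group on the ring amine nitrogen moves this assay, whereas a number 9.4 percentage points higher from compound 1 to compound 2 (within the scatter) stays within the noise. Compound 4 `Nc1scc(CN2CCN(c3ccc(F)cc3F)CC2)c1C(=O)c1ccc(Cl)cc1` differs from compound 3 only in 2,4-difluorophenyl in place of 3-fluorophenyl on an amine nitrogen in a ring. Compound 1, which carries 4-chloro-2-fluorophenyl at the same place and stands higher than compound 3, is the closest measured guide, so a modest upward step is expected for compound 4, a number 17 percentage points higher from compound 3 to compound 4 (beyond the scatter). Compound 4 is therefore estimated at -20%, with a range from -40% to 0%.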

Compound 4, a percentage reported as activity, at one concentration (the size of the read-out at that concentration, not a potency): -17%
For compound 4 the middle estimate is 3 percentage points below the measured one; measured number inside the range.
By their numbers in this assay, from the lowest: compound 3; then compounds 4, 1 and 2 (each within the scatter of the next, the first and the last beyond it).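

In this assay, 2,4-difluorophenyl in place of 3-fluorophenyl gives a number 20 percentage points higher from compound 3 to compound 4 (beyond the scatter), so a second fluoro on this aryl group does not keep the lowest number, which stays with compound 3. Fluoro in place of chloro on an aromatic carbon gives a number 7.6 percentage points lower from compound 1 to compound 4 (within the scatter), so this halogen exchange is not resolved here, while a number 17 percentage points lower from compound 2 to compound 4 (beyond the scatter) separates compound 4 from the naphthalen-1-yl compound. No supporting data explain these differences. The compounds shown leave open how a methoxy group or a nitrile on this phenyl ring would read, and whether an unsubstituted phenyl would stand nearer compound 3 or compound 4.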